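Adding a Second Chloro: What Cytotoxicity to Expect

The source may hold more compounds than are shown below. What is called first, only, known or untested is meant among the compounds shown, and "the series" means these compounds.

Compound 1 `ClCc1ccc(Cn2cnc3c(Cl)ncnc32)cc1` carries a single chloro on its shared core. In a functional assay on T47D cells (Homo sapiens) for cytotoxicity, read by sulforhodamine B assay, with a stated time of 48 h (on this read-out lower numbers stand for higher toxicity in this test and higher numbers for lower toxicity in this test), compound 1 gives "not determined" (no result reported), so no number stands for compound 1 on this read-out. Two related compounds, each carrying two chloro groups on the same core, have been tested. Compound 2 `ClCc1cccc(Cn2cnc3nc(Cl)nc(Cl)c32)c1` gives in this assay a result of > 100000 nM, which is a limit of the assay and not a number. Compound 3 `ClCc1ccccc1Cn1cnc2nc(Cl)nc(Cl)c21` likewise gives in this assay a result of > 100000 nM, again a limit rather than a number. Taken together, the limit of > 100000 nM in this assay, at which 2 of the 3 values shown sit, is all that has been seen so far: no compound here has a lethal concentration on this read-out that could be pinned down.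

Compound 4 `ClCc1ccc(Cn2cnc3c(Cl)nc(Cl)nc32)cc1` is compound 1 with one change: chloro in place of hydrogen on an aromatic carbon. Within the data shown here, no step between measured compounds is available, so the size of any step in this assay cannot be read from data. Compound 2 and compound 3, which also carry two chloro groups, both sit at the limit of > 100000 nM in this assay, at which 2 of the 3 values shown sit, and compound 4 is expected to sit there as well, with no step beyond the scatter visible. For compound 4 the value in this assay is estimated at 150000 nM, within an expected range from 60000 nM to 400000 nM.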

Compound 4, concentration lethal to 50% of the cells: > 100000 nM
Compound 4 ended at the assay's limit; the forecaster's own chance of this, stated with the estimate: 80%; the middle value is on the limit's open side.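

In this assay compound 4 gives > 100000 nM, which is a limit of the assay and not a number. Compound 1 gives "not determined" (no result reported), so no step can be read between compound 1 and compound 4. The compounds shown leave open whether the added chloro changes cytotoxicity at all, and what lethal concentration any of them has: the limit of > 100000 nM in this assay, at which 3 of the 4 values shown sit.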